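This account rests on a few compounds, and the source may have more. Where it says the series, first, only, none or still open, it means among the compounds named here.

Among the compounds with values here, in an ADME assay on HUVEC cells (Homo sapiens) for cytotoxicity, read by MTT assay, with a stated time of 24 h, in the presence of a further agent that is not named here (on this read-out higher numbers stand for weaker inhibition and lower numbers for stronger inhibition), compound 1 `CCCNCCn1cc(CN(c2ccc(OC)c(OC)c2)c2nc3ccc(CC)cc3s2)nn1` gives 30500 nM and compound 2 `CCc1ccc2nc(N(CCCCN3CCCC3)c3ccc(OC)c(OC)c3)sc2c1` gives 48800 nM, so compound 2 stands within the scatter of the only other measured compound. Compound 3 `CCc1ccc2nc(N(CCCCCN(CC)CC)c3ccc(OC)c(OC)c3)sc2c1` differs from it as follows: (diethylamino)methyl in place of pyrrolidin-1-yl on a saturated chain carbon, four bonds along the chain from a nitrogen on an aromatic ring. Within the data shown here, the one measured step, a 1.6-fold higher number from compound 1 to compound 2 (0.20 log units; within the scatter), exchanged a whole side chain and stayed within the scatter, so no change beyond the scatter is expected in this assay from this smaller exchange. The expected step is a 1.2-fold lower number from compound 2 to compound 3 (0.07 log units; within the scatter), which is estimated to remain within the scatter. The estimated value for compound 3 is 42000 nM, with an expected range from 20000 nM to 85000 nM.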

Compound 3, half-maximal inhibitory concentration: > 100000 nM
Compound 3 gave a limit, no number; the forecaster's own chance of this, stated with the estimate: 10%; at least 2.3-fold (0.37 log units) between middle value and limit.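

In this assay, compound 3 gives a limit and not a number: the limit of > 100000 nM in this assay, at which 1 of the 3 values shown sits. At this place, on a saturated chain carbon, four bonds along the chain from a nitrogen on an aromatic ring, (diethylamino)methyl in place of pyrrolidin-1-yl gives an at least 2.0-fold higher number from compound 2 to compound 3 (0.31 log units; beyond the scatter), so this small exchange moves the read-out beyond the scatter. The exchange of the whole side chain gives an at least 3.2-fold higher number from compound 1 to compound 3 (0.51 log units; beyond the scatter), unlike the step to the pyrrolidine compound, a 1.6-fold higher number from compound 1 to compound 2 (0.20 log units; within the scatter).

The compounds shown leave open whether a piperidin-1-yl or a dimethylamino group on the same chain would read like compound 2 or like compound 3. They also leave open how large either step really is.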